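This account rests on a few compounds, and the source may have more. Where it says the series, first, only, none or still open, it means among the compounds named here.

Three measured compounds share one core and differ only in the groups on their two outer aromatic rings: compound 1 is `N#Cc1cccc(C(=O)N2CCCC(C(=O)Nc3ccc(Cl)cc3)C2)c1`, compound 2 is `CCc1cccc(NC(=O)C2CCCN(C(=O)c3cc(C(F)(F)F)cc(C(F)(F)F)c3)C2)c1` and compound 3 is `O=C(Nc1cccc(Cc2ccccc2)c1)C1CCCN(C(=O)c2cccc(-c3ccco3)c2)C1`. In an ADME assay on PC-3 cells (Homo sapiens) for cytotoxicity, read by WST assay, tested at 100 uM (a lower number here means less inhibition, a higher number more inhibition at the concentration tested (going by the name of the read-out)), compound 1 gives 0%. In the same assay compound 2 gives 0% and compound 3 gives 0%. Compound 1 therefore stands level with compounds 2 and 3 at the digits shown; its nearest neighbour is compound 2 and its furthest is compound 3, and neither gap goes outside the usual scatter of this read-out. Among the measured compounds shown here, no pair of measured compounds differs in a single place, so there is no measured step to calibrate how far a single change on an outer ring moves the read-out; the flat spread across compounds 1, 2 and 3 is the only guide.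

Compound 4 is `CC(=O)Nc1cccc(C(=O)N2CCCC(C(=O)Nc3ccc(Cl)cc3)C2)c1`. It differs from compound 1 in one place: acetamido in place of cyano on an aromatic carbon. Given that compound 1 sits at 0% and the other two compounds show no movement with quite different ring substitution, the step from compound 1 to compound 4 is expected to be no change at the digits printed from compound 1 to compound 4 (within the scatter), none beyond the scatter. For compound 4 the estimate in this assay is 0%, with a range from -8% to 10%.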

Compound 4, a percentage reported as inhibition, at one concentration (the size of the read-out at that concentration, not a potency): 4%
Compound 4: middle estimate off by 4 percentage points, on the low side, within the range that was stated.
By their numbers in this assay, from the lowest: compounds 1, 2, 3 and 4 (each within the scatter of the next).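

In this assay, among the compounds shown here, the only single-place step is a number 4 percentage points higher from compound 1 to compound 4 (within the scatter) and it comes from acetamido in place of cyano on an aromatic carbon, meta to a large group. This position therefore takes a larger group carrying a hydrogen-bond donor, which cyano lacks, with the read-out staying within the scatter; compounds 1, 2 and 3 differ in more than one place and could not show this for a single position. Nothing at hand gives a reason for this outcome.

The compounds shown leave open whether an amine or a carboxylic acid on this aromatic carbon, both of which would bring a group of a different kind from cyano and acetamido, would move the read-out beyond the scatter. They also leave open whether the swap from cyano to acetamido would read the same with a different group on the other outer ring, as this one step rests on the pair of compound 1 and compound 4 alone.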